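The source may report more compounds than this note shows. Statements on the series, on what has been measured and on what is new or still open speak of the compounds shown alone.

Of the compounds shown here, two that share one core have so far been measured in an assay on HEK293 cells for inhibition of N-acylethanolamine-hydrolyzing acid amidase (Rattus norvegicus), read by LC-MS, with a stated time of 30 min; on this read-out higher numbers stand for weaker inhibition and lower numbers for stronger inhibition. Compound 1 `O=C(CCc1ccc(-c2cccc(Cl)c2)cc1)N1CCCC1` gives 25400 nM in this assay. Compound 2 `O=C(CCc1ccc(-c2ccc(Cl)cc2)cc1)N1CCCC1` gives 48600 nM in this assay; the two numbers lie within the scatter of each other, so neither compound can be called the stronger or weaker inhibitor on this evidence.

Compound 3 `O=C(CCc1ccc(-c2ccsc2)cc1)N1CCCC1` has not yet been measured. It differs from compound 2 in one place: thiophen-3-yl in place of 4-chlorophenyl on an aromatic carbon. Among the measured compounds shown here, the single measured step, a 1.9-fold higher number from compound 1 to compound 2 (0.28 log units; within the scatter), moved a chlorine from one position of a phenyl ring to another and was within the scatter. For the measured compounds named here, that step does not concern the exchange of a whole six-membered ring for a five-membered one, so there is no direct precedent for the change from compound 2 to compound 3. With no shown step beyond the scatter, the expectation for compound 3 in this assay is a number close to that of compound 2, and the estimated step of a 1.2-fold lower number from compound 2 to compound 3 (0.08 log units; within the scatter) is taken as none beyond the scatter. The estimate for compound 3 is therefore 40000 nM, with a range from 12000 nM to 130000 nM.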

Compound 3, half-maximal inhibitory concentration: 2500 nM
Estimate against measurement, compound 3: 16-fold (1.20 log units) above, outside the stated range (below it).
By their numbers in this assay, from the lowest: compound 3; then compounds 1 and 2 (each within the scatter of the next).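

Among the compounds shown here, on this aromatic carbon, para to a group of 9 heavy atoms, the earlier compounds showed only that moving a chlorine around a phenyl ring left this assay within the scatter, whereas exchanging the whole ring has a large effect: thiophen-3-yl in place of 4-chlorophenyl gives a 19-fold lower number from compound 2 to compound 3 (1.29 log units; beyond the scatter), and in place of 3-chlorophenyl it gives a 10-fold lower number from compound 1 to compound 3 (1.01 log units; beyond the scatter). The position is therefore sensitive to which ring it carries, and both chlorinated compounds lead to the same reading. The exchange alters several things at once, since the entering group has 5 heavy atoms rather than 7, a five-membered aromatic ring, a sulfur in place of a chlorine and 1 hydrogen-bond acceptor rather than 0, and no experimental information here connects any of these differences to the result.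

As far as these compounds go, what stays open is which of those differences matters, a question that an unsubstituted phenyl, a thiophen-2-yl or a furan-3-yl on the same carbon could help to separate. Also open, from the compounds shown here alone, is whether the thiophen-3-yl result would hold with a longer chain leading to the carbonyl, or with an amine on the thiophene ring.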